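The source may report more compounds than this note shows. Statements on the series, on what has been measured and on what is new or still open speak of the compounds shown alone.

Measured so far:
- compound 1, `C[C@H](NC(=O)Nc1cccc(Br)c1)c1ccccc1`: 99%
- compound 2, `C[C@@H](NC(=O)Nc1ccc(Br)cc1)c1ccccc1`: 87%
- compound 3, `C[C@H](NC(=O)Nc1cccc(I)c1)c1ccccc1`: 93%

Of the compounds shown here, three have been tested in an ADME assay on the whole organism with Oryza sativa as the target, tested at 10 uM; a lower number here means a stronger effect, a higher number a weaker effect of the compound at the concentration tested. In this assay compound 1 gives 99%, and compound 3 gives 93%. The two share a core and differ in one group: iodo in place of bromo on an aromatic carbon. That change gave a step of a number 6 percentage points lower from compound 1 to compound 3 (within the scatter). Compound 2, with 87%, sits within the scatter of compound 3 but beyond it from compound 1. How the core of compound 2 differs from the core of compound 1 is not broken down here; the two are built from the same atoms joined differently.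

Compound 4, `C[C@@H](NC(=O)Nc1ccc(I)cc1)c1ccccc1`, has not been measured. Its relation to compound 2 is iodo in place of bromo on an aromatic carbon. Going by the values given here, this is the same kind of change as the one from compound 1 to compound 3, but not the same: in compound 3 the iodo sits meta to a large group, in compound 4 it sits para to a large group.

Among the compounds with values here, from compound 2 to compound 4, a step of about a number 5 percentage points lower from compound 2 to compound 4 (within the scatter) is expected in this assay, because the one measured example, a number 6 percentage points lower from compound 1 to compound 3 (within the scatter), stayed within the scatter. Compound 4 is therefore estimated at 82%, most likely between 65% and 97%. This rests on a single precedent at a different place on the ring, so the estimate is loosely held.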

Compound 4, a percentage reported as activity, at one concentration (the size of the read-out at that concentration, not a potency): 85%
Compound 4: middle estimate off by 3 percentage points, on the low side, within the range that was stated.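

In this assay, putting iodo in place of bromo on the aromatic carbon para to a large group gave a number 2 percentage points lower from compound 2 to compound 4 (within the scatter). Set beside the earlier example of the same exchange, the new step tells the same story, so in this small series the change carries over from one core to the other without a readable difference in size: the same change on two cores in this assay, a number 6 percentage points lower (within the scatter) from compound 1 to compound 3 and a number 2 percentage points lower (within the scatter) from compound 2 to compound 4, 4 percentage points apart, within the scatter of two such steps What this does not show is a true effect of a particular size or a rule for the wider series, since both steps lie within the scatter and rest on only two pairs of compounds, so the result says only that no effect of this exchange could be told apart from the scatter on either core.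

The compounds shown carry only bromo and iodo on this ring, so they leave open whether a quite different group in the place of the halogen, such as an amine, a carboxylic acid or a longer chain, would give a step beyond the scatter. They also leave open whether such a group would behave alike on both cores, which is the question the two halogen pairs could answer only for this one exchange.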